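Ester chain extension in a thioester amide series

The source may hold more compounds than are shown below. What is called first, only, known or untested is meant among the compounds shown, and "the series" means these compounds.

Measured compounds and their values:
compound 1, `CCCCOC(=O)[C@@H](N)CCC(=O)NCCSC(=O)C(C)(C)C`, 0.167 h
compound 2, `CCCOC(=O)[C@@H](N)CCC(=O)NCCSC(C)=O`, 0.167 h

In an ADME assay on liver for metabolic stability, with liver carboxylesterase 1 (Homo sapiens) as the target (on this read-out higher numbers stand for a longer-lived compound and lower numbers for a shorter-lived compound), compound 1 gives 0.167 h. Compound 2 gives 0.167 h in this assay. Compound 2 thus stands level with compound 1 at the digits shown; the nearest neighbour is compound 1, and the two values show no change within the scatter. Among the measured compounds shown here, no step between measured compounds that differ in a single place is available, and compound 1 and compound 2 differ in more than one place, so their equal values cannot be assigned to either difference.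

The next compound is compound 3, `CCCCOC(=O)[C@@H](N)CCC(=O)NCCSC(C)=O`, still to be measured in this assay. It differs from compound 2 by methyl in place of hydrogen on a saturated chain carbon, three bonds along the chain from an oxygen next to a carbonyl group; cut one bond further out, the same difference reads propyl to butyl. Because compound 1 gives 0.167 h and compound 2 gives 0.167 h, the data so far show no movement across this series, and no step beyond the scatter is expected for compound 3: a 1.0-fold higher number from compound 2 to compound 3 (0.01 log units; within the scatter). Compound 3 is estimated at 0.17 h, with a range from 0.08 h to 0.35 h.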

Compound 3, half-life in the liver carboxylesterase 1 assay: 0.167 h
Compound 3: the middle estimate sits 1.0-fold (0.01 log units) above what was measured, and the stated range covers the measured number.
By their numbers in the liver carboxylesterase 1 assay, from the lowest: compounds 1, 2 and 3 (each within the scatter of the next).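

In the liver carboxylesterase 1 assay, methyl in place of hydrogen on a saturated chain carbon, three bonds along the chain from an oxygen next to a carbonyl group, the propyl to butyl difference, gives no change at the digits printed from compound 2 to compound 3 (within the scatter). Methyl in place of tert-butyl on a carbonyl carbon gives no change at the digits printed from compound 1 to compound 3 (within the scatter), so each of these two positions now has a comparison in a single place, and neither separates the compounds on half-life. In a physicochemical assay for lipophilicity, at pH 7.4 (on this read-out lower numbers stand for lower lipophilicity and higher numbers for higher lipophilicity), compound 2 gives -1.21 and compound 3 gives -0.88. The propyl to butyl difference is nonetheless visible in the physicochemical assay, where a modest measured rise in lipophilicity at this position comes with a half-life level within the scatter: the measured distribution coefficient of compound 2, -1.21, and of compound 3, -0.88, a number 0.33 log units higher (beyond the scatter)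

Among the compounds shown here, all three compounds print the same half-life, so the series so far gives no handle on which part of the structure governs it. Still open, on these data alone, is whether a longer chain at this position, a carboxylic acid in place of the ester, or an amide in place of the thioester would separate from these compounds in the liver carboxylesterase 1 assay.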